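From 4-methoxyphenyl to furan-3-yl on the shared core

This account rests on a few compounds, and the source may have more. Where it says the series, first, only, none or still open, it means among the compounds named here.

Measured so far in an ADME assay on BHK-21 cells (Mesocricetus auratus) for cytotoxicity, read by MTT assay; a lower number here means that less compound is tolerated, a higher number that more compound is tolerated
- compound 1 `CC(=O)c1ccc2c(c1)nc(-c1ccccc1)n2C1CCCCC1` gives 100000 nM
- compound 2 `CC(=O)c1ccc2c(c1)nc(-c1ccc(Cl)cc1)n2C1CCCCC1` gives > 100000 nM as a limit
- compound 3 `COc1ccc(-c2nc3cc(C(C)=O)ccc3n2C2CCCCC2)cc1` gives > 100000 nM as a limit

Compound 3 gives > 100000 nM in this assay and this is a limit and not a number. Compound 3 stands at the limit of > 100000 nM in this assay, at which 2 of the 3 values shown sit, and so has no exact place on the numbers.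

The change to compound 4 `CC(=O)c1ccc2c(c1)nc(-c1ccoc1)n2C1CCCCC1` is furan-3-yl in place of 4-methoxyphenyl on an aromatic carbon with furan-3-yl in place of 4-methoxyphenyl on an aromatic carbon. For the measured compounds named here, no measured step covers this exchange directly. Going by the values given here, three measured steps bear on it: a number no lower from compound 1 to compound 2 (the limit leaves the size open) and a number no lower from compound 1 to compound 3 (the limit leaves the size open) and a step that the two limits leave unreadable from compound 2 to compound 3 and none of them has a readable size.

Among the compounds with values here, compound 1 carries a number of 100000 nM and no measured step shows a lower value, so no step beyond the scatter is expected in this assay and no direction can be favoured. The step expected for this exchange is a number no higher from compound 3 to compound 4 (the limit leaves the size open) and it is only an estimate. Compound 4 is estimated at 100000 nM with an expected range from 40000 nM to 200000 nM and the result may well come back as a limit only.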

Compound 4, half-maximal cytotoxic concentration: 77000 nM
For compound 4 the middle estimate is 1.3-fold (0.11 log units) above the measured one; the measured number falls inside the stated range.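

In this assay, the exchange of a six-membered aromatic ring of carbon only for furan-3-yl at this position, between two ring nitrogen atoms, gives a 1.3-fold lower number from compound 1 to compound 4 (0.11 log units; within the scatter). Against the two para-free names of the series, 4-methoxyphenyl and 4-chlorophenyl, the steps are an at least 1.2-fold lower number from compound 3 to compound 4 (0.11 log units; that floor lies within the scatter) and an at least 1.2-fold lower number from compound 2 to compound 4 (0.11 log units; that floor lies within the scatter), so each has only a floor and its full size stays open. Compound 4 is the first in the series with a five-membered aromatic ring with 1 hetero atom at this place, and it carries an exact number, while compound 2 and compound 3 each give only a limit: the limit of > 100000 nM in this assay, at which 2 of the 4 values shown sit.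

The step between compound 2 and compound 3 cannot be read, and no step shown at this position lies beyond the scatter, so how far this place can move the number in this assay remains unknown. Also open, on these data alone, is whether a phenyl ring carrying an amine or a carboxylic acid, or a longer chain in place of the ring at this position, would give a step beyond the scatter from compound 1.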